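A few compounds are considered here, and "the series" means these few. Any claim that something is new, unique, unknown or untested is made for them only; others in the source may bear on it.

Compound 2 `N#C/C=C/c1ccc(C(NN)c2ccnc(Nc3ccc(C#N)cc3)n2)cc1` is one of three measured compounds that share a core carrying a nitrile-substituted anilino group and a second aryl ring on a substituted carbon. In an ADME assay on MT4 cells (Homo sapiens) for cytotoxicity, read by MTT assay, with a stated time of 5 days (a higher number here means that more compound is tolerated, a lower number that less compound is tolerated), compound 2 gives 186000 nM, the highest of the three numbers. Compound 1 `CCNC(c1ccc(C#N)cc1)c1ccnc(Nc2ccc(C#N)cc2)n1` gives 158000 nM in this assay, which sits within the scatter of compound 2. Compound 3 `N#Cc1ccc(Nc2nccc(C(NC3CC3)c3ccc(C#N)cc3)n2)cc1` gives 34700 nM, the furthest from compound 2 and beyond the scatter. For the measured compounds named here, the only single-point step among the measured compounds is a 4.6-fold lower number from compound 1 to compound 3 (0.66 log units; beyond the scatter), a change made on the same amine nitrogen that is altered here.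

Compound 4 `CNC(c1ccc(/C=C/C#N)cc1)c1ccnc(Nc2ccc(C#N)cc2)n1` differs from compound 2 by methyl in place of amino on an amine nitrogen. Going by the values given here, no measured pair shows exactly this exchange, so the step from compound 1 to compound 3 is the nearest guide: a substituent swap on that nitrogen moved the number modestly, and in the downward direction. The present change is smaller in bulk and is therefore expected to give, if anything, a smaller shift, and quite possibly none beyond the scatter.

Compound 4 is therefore estimated at 130000 nM in this assay, within a range from 50000 nM to 300000 nM, meaning an expected step of a 1.4-fold lower number from compound 2 to compound 4 (0.16 log units; within the scatter).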

Compound 4, half-maximal cytotoxic concentration: 41400 nM
Beside the measured number, compound 4's estimate is 3.1-fold (0.50 log units) above it, outside the stated range (below it).
By their numbers in this assay, from the lowest: compounds 3 and 4 (each within the scatter of the next); then compounds 1 and 2 (each within the scatter of the next).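

In this assay, methyl in place of amino on the amine nitrogen gives a 4.5-fold lower number from compound 2 to compound 4 (0.65 log units; beyond the scatter), showing that exchanging a single heavy atom at this position, nitrogen for carbon, is enough to move the number beyond the scatter. The earlier evidence at this nitrogen was a 4.6-fold lower number from compound 1 to compound 3 (0.66 log units; beyond the scatter), a swap of one carbon substituent for another in a pair with a different second aryl ring; there are now two modest steps at this nitrogen, both downward, and the new one starts from amino. Nothing at hand explains why either number moves.

The compounds shown leave open whether the higher number of compound 2 is particular to amino or would also appear with another group on this nitrogen, such as a hydroxyl group, a dimethylamino group or a longer chain. They also leave open how much the second aryl ring contributes, since no pair shown differs only in that ring, and whether the same exchange would give a step of similar size on the ring of compound 1.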